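1H-pyrrol-2-yl replacing methoxycarbonyl: cytotoxicity outlook

This account rests on a few compounds, and the source may have more. Where it says the series, first, only, none or still open, it means among the compounds named here.

Compound 2 `COC(=O)c1ccc(NCc2cncn2Cc2ccc(-c3ccccc3)cc2)cc1-c1ccccc1` belongs to the same series as compound 1 `COC(=O)c1ccc(NCc2cncn2Cc2cccc(C)c2)cc1-c1ccccc1`. In a toxicity assay on NIH3T3 cells (Mus musculus) for cytotoxicity, read by resazurin assay (a lower number here means that less compound is needed, a higher number that more compound is needed for the effect), compound 2 gives only a limit, > 1000 nM. In this assay compound 1 likewise gives only a limit, > 10000 nM. The step that the two limits leave unreadable from compound 1 to compound 2 cannot be sized, since the limit of > 1000 nM in this assay, at which 1 of the 2 values shown sits, and the limit of > 10000 nM in this assay, at which 1 of the 2 values shown sits, mark both of its ends. Compound 2 thus stands at a limit in this assay, with no readable step around it.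

Compound 3 `c1ccc(-c2ccc(Cn3cncc3CNc3ccc(-c4ccc[nH]4)c(-c4ccccc4)c3)cc2)cc1` differs from compound 2 by 1H-pyrrol-2-yl in place of methoxycarbonyl on an aromatic carbon. Within the data shown here, no measured step bears on this change; the single step in this assay is unreadable, so nothing in the numbers supports a shift in either direction. The step that the limit leaves unreadable from compound 2 to compound 3 is therefore expected to stay within the scatter, and another limit is the likelier outcome. For compound 3 the estimated value in this assay is 10000 nM, with a range from 2000 nM to 50000 nM.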

Compound 3, half-maximal effective concentration: > 10000 nM
Compound 3: a limit, no number; the forecaster's own chance of this, stated with the estimate: 70%; the middle value lies on the limit itself.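

Compound 2 and compound 3 both give only limits in this assay, and no step can be read between them. Still open is the concentration at which any compound shown reaches the half-maximal effect, and therefore how 1H-pyrrol-2-yl compares with methoxycarbonyl in size of effect.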